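The source may hold more compounds than are shown below. What is called first, only, known or untested is meant among the compounds shown, and "the series" means these compounds.

Measured so far:
Compound 1 `C=C1[C@@H](OC(C)=O)C[C@@H]2[C@](C)(CO[Si](C)(C)C(C)(C)C)[C@H](OC(C)=O)CC[C@@]2(C)[C@@H]1C[C@@H](Nc1ccc(C(=O)O)cc1)C1=CCOC1=O` gives 4630 nM in a functional assay on HT-29 cells (Homo sapiens) for cytotoxicity, read by sulforhodamine B assay; on this read-out lower numbers stand for stronger inhibition and higher numbers for weaker inhibition.
Compound 2 `C=C1[C@@H](OC(C)=O)C[C@@H]2[C@](C)(CO[Si](C)(C)C(C)(C)C)[C@H](OC(C)=O)CC[C@@]2(C)[C@@H]1C[C@@H](Nc1cccc2ccccc12)C1=CCOC1=O` gives 15000 nM in this assay.

Among the compounds with values here, compound 2 stands at the highest of the two numbers in this assay; its nearest neighbour is compound 1, and the one measured step reads a 3.2-fold higher number from compound 1 to compound 2 (0.51 log units; beyond the scatter). Compound 3 `C=C1[C@@H](OC(C)=O)C[C@@H]2[C@](C)(CO[Si](C)(C)C(C)(C)C)[C@H](OC(C)=O)CC[C@@]2(C)[C@@H]1C[C@@H](Nc1ccccc1C(=O)O)C1=CCOC1=O` keeps the shared core and the aminated ring system of compound 2, and differs from it in one place: 2-carboxyphenyl in place of naphthalen-1-yl on an amine nitrogen.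

Within the data shown here, the only step that bears on this change is the one from compound 1 to compound 2, where a 4-carboxyphenyl was exchanged for naphthalen-1-yl and the number rose by a 3.2-fold higher number from compound 1 to compound 2 (0.51 log units; beyond the scatter). Compound 3 runs that exchange backwards in kind, returning from naphthalen-1-yl to a carboxyphenyl, though with the carboxyl in the 2-position rather than the 4-position, so the earlier step gives only a loose guide. Compound 3 is therefore expected to show a lower number than compound 2, a step of about a 2.3-fold lower number from compound 2 to compound 3 (0.36 log units; beyond the scatter), with the uncertainty of the shifted carboxyl widening the range. The estimate for compound 3 in this assay is 6500 nM, within 2500 nM to 17000 nM.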

Compound 3, half-maximal inhibitory concentration: 5340 nM
Estimate against measurement, compound 3: 1.2-fold (0.09 log units) above; the range from low to high includes it.
By their numbers in this assay, from the lowest: compounds 1 and 3 (each within the scatter of the next); then compound 2.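

In this assay, 2-carboxyphenyl in place of naphthalen-1-yl on the amine nitrogen gives a 2.8-fold lower number from compound 2 to compound 3 (0.45 log units; beyond the scatter), so a second carboxyphenyl group now stands apart from the naphthalen-1-yl group of compound 2, and the earlier contrast no longer rests on compound 1 alone. The new comparison between the two carboxyphenyl groups gives a 1.2-fold higher number from compound 1 to compound 3 (0.06 log units; within the scatter), so compound 1 and compound 3 cannot be told apart, and exchanging 4-carboxyphenyl for 2-carboxyphenyl leaves no readable mark on this cytotoxicity measure. Nothing available explains the gap between these carboxyphenyl groups and naphthalen-1-yl.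

As far as these compounds go, it remains open whether the carboxylic acid itself separates compound 1 and compound 3 from compound 2, or whether a plain phenyl group, a methyl ester or a primary amide on the same amine nitrogen would read alike. From the compounds shown here alone, it is also open how a free hydroxyl group in place of the silyl ether on the shared core would alter the numbers for any of these amine substituents.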